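Trimming the Para Substituent: Isopropyl to Methyl on Compound 3

The source may report more compounds than this note shows. Statements on the series, on what has been measured and on what is new or still open speak of the compounds shown alone.

Three measured compounds share one core and differ in the group attached to the nitrogen on the aromatic ring. Compound 1 `CC(C)c1ccc(-c2nc(SCc3cn(CC(=O)NC(=O)Nc4ccccn4)nn3)nc(Nc3cccc(Cl)c3)c2C#N)cc1` gives 18000 nM in a functional assay on MCF7 cells (Homo sapiens) for inhibition, read by MTT assay, with a stated time of 72 h; on this read-out higher numbers stand for weaker inhibition and lower numbers for stronger inhibition. Compound 3 `COc1ccccc1Nc1nc(SCc2cn(CC(=O)NC(=O)Nc3ccccn3)nn2)nc(-c2ccc(C(C)C)cc2)c1C#N` gives 19300 nM in this assay, a value that sits within the scatter of compound 1, so the two cannot be ranked; the step of a 1.1-fold higher number from compound 1 to compound 3 (0.03 log units; within the scatter) confirms this. For compound 2 `CC(C)c1ccc(-c2nc(SCc3cn(CC(=O)NC(=O)Nc4ccccn4)nn3)nc(Nc3ccccc3F)c2C#N)cc1` this assay reports only a limit, > 64000 nM, not a number. Accordingly the steps of an at least 3.5-fold higher number from compound 1 to compound 2 (0.55 log units; beyond the scatter) and an at least 3.3-fold lower number from compound 2 to compound 3 (0.52 log units; beyond the scatter) are at least modest, and compound 2 is the one that sits at the limit (the limit of > 64000 nM in this assay, at which 1 of the 3 values shown sits).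

Compound 4 `COc1ccccc1Nc1nc(SCc2cn(CC(=O)NC(=O)Nc3ccccn3)nn2)nc(-c2ccc(C)cc2)c1C#N` is not yet measured. It differs from compound 3 by methyl in place of isopropyl on an aromatic carbon. Among the compounds with values here, none of the measured steps touches this position; all three change the group on the nitrogen instead, so no measured step bears directly on it. With no evidence either way, the expected step of a 1.1-fold higher number from compound 3 to compound 4 (0.06 log units; within the scatter) is none beyond the scatter, and compound 4 is estimated at 22000 nM in this assay, within the range 8000 nM to 60000 nM.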

Compound 4, half-maximal inhibitory concentration: 19700 nM
For compound 4 the middle estimate is 1.1-fold (0.05 log units) above the measured one; measured number inside the range.
By their numbers in this assay, from the lowest: compounds 1, 3 and 4 (each within the scatter of the next). At a limit, above all of these: compound 2.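

Within the data shown here, this is the first measured change at the aromatic carbon that carries the isopropyl group, as all the earlier steps altered the group on the nitrogen. Replacing isopropyl with methyl gives a 1.0-fold higher number from compound 3 to compound 4 (0.01 log units; within the scatter) in this assay, so with the 2-methoxyphenyl group on the nitrogen, the 4-isopropylphenyl and 4-methylphenyl versions cannot be ranked. The data shown offer no explanation for this result.

The compounds shown leave open whether this position would tolerate a different kind of group, such as an amine, a carboxylic acid or a longer chain, or bare hydrogen with no group at all. On these data alone, it also remains open whether the same swap would read alike with the 3-chlorophenyl group of compound 1 on the nitrogen.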